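The source may report more compounds than this note shows. Statements on the series, on what has been measured and on what is new or still open speak of the compounds shown alone.

Compound 1 `COc1cc2c(Oc3ccc(NC(=O)c4cn(-c5ccccc5)nn4)cc3F)ccnc2cc1OCCCN1CCCC1` carries a shared core whose aromatic amide is tied to a triazole bearing a plain phenyl ring. In a functional assay on NCI-H460 cells (Homo sapiens) for cytotoxicity, read by MTT assay, with a stated time of 72 h (on this read-out higher numbers stand for weaker inhibition and lower numbers for stronger inhibition), compound 1 gives 280 nM. Within the data shown here, two neighbours change only that phenyl ring. Compound 2 `COc1cc2c(Oc3ccc(NC(=O)c4cn(-c5ccccc5Cl)nn4)cc3F)ccnc2cc1OCCCN1CCCC1` gives 190 nM, and a 1.5-fold lower number from compound 1 to compound 2 (0.17 log units; within the scatter). Compound 3 `COc1cc2c(Oc3ccc(NC(=O)c4cn(-c5ccc(Br)cc5)nn4)cc3F)ccnc2cc1OCCCN1CCCC1` gives 200 nM, and a 1.4-fold lower number from compound 1 to compound 3 (0.15 log units; within the scatter). Between them, a 1.1-fold higher number from compound 2 to compound 3 (0.02 log units; within the scatter). So the number of compound 1 is the highest of the three, yet every step among these three compounds lies within the scatter, and no compound can be called more or less potent than another on this evidence.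

Compound 4 `COc1cc2c(Oc3ccc(NC(=O)c4cn(-c5ccccc5)nn4)cc3F)ccnc2cc1OCCCN1CCCCC1` leaves the phenyl ring untouched and instead alters the far end of the side chain: piperidin-1-yl in place of pyrrolidin-1-yl on a saturated chain carbon, three bonds along the chain from an oxygen on an aromatic ring. Among the measured compounds shown here, none of the measured steps touches this side chain; all three concern the phenyl ring on the triazole, and all three stayed within the scatter. For the measured compounds named here, there is therefore no measured step that bears directly on the change from compound 1 to compound 4, and the only guide is that the small changes seen so far moved the numbers little. The expectation is that no change at the digits printed from compound 1 to compound 4 (within the scatter), a step not beyond the scatter. Compound 4 is estimated at 280 nM, within a range from 120 nM to 650 nM.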

Compound 4, half-maximal inhibitory concentration: 210 nM
The estimate for compound 4 lay 1.3-fold (0.12 log units) above the measured number, and the stated range covers the measured number.
By their numbers in this assay, from the lowest: compounds 2, 3, 4 and 1 (each within the scatter of the next).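

Among these compounds, this is the first change at the far end of the side chain, and in this assay putting piperidin-1-yl in place of pyrrolidin-1-yl gives a 1.3-fold lower number from compound 1 to compound 4 (0.12 log units; within the scatter). The ring that enters has one carbon more than the ring that leaves, yet this step does not separate the two compounds, so compound 1 and compound 4 must be treated as equal on this evidence, and a change at this end of the molecule has so far done no more than the changes on the phenyl ring. No measurement shown offers an explanation for this result.

Going by these compounds, it remains open whether a different kind of group at this end, such as morpholin-4-yl or an open-chain dimethylamino group, or a chain shorter or longer than the one in 3-(piperidin-1-yl)propyl, would move the number beyond the scatter. On these data alone, it is also open whether piperidin-1-yl would read the same alongside the 2-chlorophenyl or 4-bromophenyl ring as it does alongside the plain phenyl ring of compound 4.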